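A few compounds are considered here, and "the series" means these few. Any claim that something is new, unique, unknown or untested is made for them only; others in the source may bear on it.

Within the shared core of compound 3 `CCCCCCCc1ccc(NC(=O)Nc2c(C(C)C)cccc2C(C)C)cc1`, the chain on the aromatic carbon is the only variable. In an assay on isolated protein for inhibition of acyl-CoA:cholesterol acyltransferase (Oryctolagus cuniculus) (a lower number here means a stronger inhibitor, a higher number a weaker inhibitor), compound 3 gives 19 nM, the lowest of the three numbers. Compound 1 `CCCCCCCCCCCCCCc1ccc(NC(=O)Nc2c(C(C)C)cccc2C(C)C)cc1` gives 500 nM and compound 2 `CC(C)c1cccc(C(C)C)c1NC(=O)Nc1ccccc1` gives 910 nM; both steps, a 26-fold lower number from compound 1 to compound 3 (1.42 log units; beyond the scatter) and a 48-fold lower number from compound 2 to compound 3 (1.68 log units; beyond the scatter), are large. Compound 4 `Cc1ccc(NC(=O)Nc2c(C(C)C)cccc2C(C)C)cc1` differs from compound 3 by hydrogen in place of hexyl on a saturated chain carbon bound to an aromatic carbon. Both steps bear on this change: removing the chain entirely in the step from compound 2 to compound 3 was the larger, and the remaining methyl keeps only a small part of the heptyl. A large rise is therefore expected, a 21-fold higher number from compound 3 to compound 4 (1.32 log units; beyond the scatter), toward the number of compound 2. For compound 4 the expected value in this assay is 400 nM, within 100 nM to 1500 nM.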

Compound 4, half-maximal inhibitory concentration: 250 nM
Estimate against measurement, compound 4: 1.6-fold (0.20 log units) above; low and high end bracket the measured number.
By their numbers in this assay, from the lowest: compound 3; then compounds 4, 1 and 2 (each within the scatter of the next, the first and the last beyond it).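

In this assay, cutting heptyl back to methyl gives a 13-fold higher number from compound 3 to compound 4 (1.12 log units; beyond the scatter) and so loses most of the gain seen with heptyl. Methyl in place of hydrogen on the aromatic carbon still gives a 3.6-fold lower number from compound 2 to compound 4 (0.56 log units; beyond the scatter) and so methyl alone already registers at this position, with the larger part of the gain lying between methyl and heptyl. Nothing at hand accounts for either step.

Chains between methyl and heptyl, such as butyl, would show how the number falls along this stretch. From the compounds shown here alone, whether an amine or a carboxylic acid at the chain end is tolerated also remains open.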